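This account rests on a few compounds, and the source may have more. Where it says the series, first, only, none or still open, it means among the compounds named here.

Two members of the series carry a measurement so far. Compound 1 `[O-][n+]1nc(NCOCc2ccc(C(F)(F)F)cc2)[n+]([O-])c2ccccc21` is the larger one; in a functional assay on PC-3 cells (Homo sapiens) for cytotoxicity, read by MTT assay, with a stated time of 72 h (on this read-out lower numbers stand for stronger inhibition and higher numbers for weaker inhibition), compound 1 gives 7650 nM. Compound 2 `COCNc1n[n+]([O-])c2ccccc2[n+]1[O-]` is the smaller one; in this assay compound 2 gives 7510 nM. Compound 2 holds the lowest of the two numbers, but compound 1 sits within the scatter of it, so no order between the two can be read. Compound 3 `CCCCCOCNc1n[n+]([O-])c2ccccc2[n+]1[O-]` is the next member and awaits measurement in this assay. The change from compound 2 to compound 3 is butyl in place of hydrogen on a saturated chain carbon bound to an oxygen on a saturated carbon. Going by the values given here, no measured pair shows a step of this kind, so nothing here tells how chain length alone moves the read-out. Among the compounds with values here, the one pointer is that compound 1, with its much larger arm, gives 7650 nM and therefore lands with compound 2 inside the scatter, which suggests the arm is tolerated rather than decisive. For compound 3 the expected step is a 1.4-fold lower number from compound 2 to compound 3 (0.14 log units; within the scatter), at most a small change that may not clear the scatter. Compound 3 is estimated at 5500 nM, with a range of 2200 nM to 14000 nM.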

Compound 3, half-maximal inhibitory concentration: 9200 nM
The estimate for compound 3 lay 1.7-fold (0.22 log units) below the measured number; the range from low to high includes it.
By their numbers in this assay, from the lowest: compounds 2, 1 and 3 (each within the scatter of the next).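

In this assay, going by these compounds alone, butyl in place of hydrogen on a saturated chain carbon bound to an oxygen on a saturated carbon gives a 1.2-fold higher number from compound 2 to compound 3 (0.09 log units; within the scatter), the only step between measured compounds that differ in one place. Cut one bond further out, the same difference reads methoxy to pentyloxy, so this position takes either group with no difference in the number that can be separated from the scatter, and a pair with two chain lengths sets no trend with length. No separate measurement on these compounds bears on this result.

Still open, from the compounds shown here alone, is whether any group at this position can move the number beyond the scatter, for instance a terminal amine or a carboxylic acid on the chain, or a chain much longer than pentyl. Also open, going by these compounds, is whether a change on the shared core, such as a chlorine in place of a hydrogen, would shift the number while the arm stays as in compound 2.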